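Swapping the phenyl for a chlorinated thiophene sulfonamide

A few compounds are considered here, and "the series" means these few. Any claim that something is new, unique, unknown or untested is made for them only; others in the source may bear on it.

Measured so far:
- compound 1 `CS(=O)(=O)c1ccc(Cc2nnc3n2N=C(c2ccccc2)CS3)cc1`: 25000 nM
- compound 2 `CS(=O)(=O)c1ccc(Cc2nnc3n2N=C(c2ccc(-c4ccccc4)cc2)CS3)cc1`: 12500 nM

In a functional assay on HT-29 cells (Homo sapiens) for cytotoxicity, read by MTT assay, with a stated time of 48 h (a higher number here means a weaker inhibitor, a lower number a stronger inhibitor), compound 1 gives 25000 nM, the highest of the two numbers; its nearest neighbour is compound 2, and a 2.0-fold lower number from compound 1 to compound 2 (0.30 log units; within the scatter). Compound 3 `CS(=O)(=O)c1ccc(Cc2nnc3n2N=C(c2cc(Cl)sc2S(N)(=O)=O)CS3)cc1` is not yet measured. It differs from compound 1 in one place: 5-chloro-2-sulfamoylthiophen-3-yl in place of phenyl on a carbon with a double bond to nitrogen. Within the data shown here, the only measured step, from compound 1 to compound 2, changes the same ring by a different route, so it bears on this step only loosely; no step beyond the scatter is expected here. Compound 3 is therefore estimated at 20000 nM (range 6000 nM to 70000 nM), meaning a 1.3-fold lower number from compound 1 to compound 3 (0.10 log units; within the scatter).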

Compound 3, half-maximal inhibitory concentration: > 100000 nM
Compound 3 ended at the assay's limit (the forecaster's own chance of this, stated with the estimate: 20%); at least 5.0-fold (0.69 log units) between middle value and limit.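

In this assay, among these compounds, replacing phenyl with 5-chloro-2-sulfamoylthiophen-3-yl gives an at least 4.0-fold higher number from compound 1 to compound 3 (0.60 log units; beyond the scatter), the first step beyond the scatter. This position on the core therefore does not accept every ring alike, and this change weakens the compound. Compound 3 stands at a limit, not at a number: the limit of > 100000 nM in this assay, at which 1 of the 3 values shown sits.

The ring, the chlorine and the sulfamoyl group all change in one step, so the compounds shown cannot separate their contributions. Going by these compounds, it remains open whether an unsubstituted thiophene, or a phenyl carrying an amine or a carboxylic acid, would behave like compound 1 or like compound 3.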